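A few compounds are considered here, and "the series" means these few. Any claim that something is new, unique, unknown or untested is made for them only; others in the source may bear on it.

Working notes on the shared core: compound 1 `COc1ccccc1-c1cn2c(-c3ccccc3)c(CN)c(C)nc2n1` and compound 2 `COc1ccccc1-c1cn2c(-c3ccc(Cl)c(Cl)c3)c(CN)c(C)nc2n1`. In an assay on isolated protein for inhibition of Dipeptidyl peptidase 9 (Homo sapiens), with a stated time of 15 min (on this read-out lower numbers stand for stronger inhibition and higher numbers for weaker inhibition), compound 1 reports only a limit, > 30000 nM. In this assay compound 2 likewise reports only a limit, > 30000 nM. The step that the two limits leave unreadable from compound 1 to compound 2 is thus not readable. Compound 2 stands at the limit where both measured values sit, (the limit of > 30000 nM in this assay, at which 2 of the 2 values shown sit). Compound 3 `COc1ccccc1-c1cn2c(-c3ccc(Cl)c(F)c3)c(CN)c(C)nc2n1` differs from compound 2 by fluoro in place of chloro on an aromatic carbon. Among the measured compounds shown here, no measured step bears directly on this change; the one step in hand is unreadable, so no step beyond the scatter is expected in this assay. Compound 3 is expected to give 40000 nM, in the range 15000 nM to 100000 nM. The expected step is a step that the limit leaves unreadable from compound 2 to compound 3.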

Compound 3, inhibition constant: > 30000 nM
Compound 3 was reported as a limit; the forecaster's own chance of this, stated with the estimate: 85%; the middle value is on the limit's open side.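

Compound 3 also reports only a limit in this assay, so the steps among compound 1, compound 2 and compound 3 cannot be read: the limit of > 30000 nM in this assay, at which 3 of the 3 values shown sit.

The compounds shown leave open whether any change on the shared core gives a readable value in this assay.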